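Working notes: isopropoxycarbonyl on compound 2

A few compounds are considered here, and "the series" means these few. Any claim that something is new, unique, unknown or untested is made for them only; others in the source may bear on it.

compound 1 `O=c1c2c(sn1-c1cc(OC3CCCC3)c(Cl)cc1F)CCCC2` gives 12900 nM
compound 2 `O=C1C2=C(CCCC2)S(=O)(=O)N1c1ccc(Cl)cc1` gives 8510 nM

In a functional assay on the whole organism for inhibition, with Scenedesmus acutus as the target, with a stated time of 20 min (on this read-out lower numbers stand for stronger inhibition and higher numbers for weaker inhibition), compound 2, at 8510 nM, lies within the usual scatter of compound 1, at 12900 nM, so these two values set no order. Compound 3 `CC(C)OC(=O)c1cc(N2C(=O)C3=C(CCCC3)S2(=O)=O)ccc1Cl` keeps the core of compound 2 and carries isopropoxycarbonyl in place of hydrogen on an aromatic carbon, ortho to a chloro group and meta to a large group (isopropoxycarbonyl in place of hydrogen on an aromatic carbon). Within the data shown here, no measured step covers such a change, so the expectation rests on the structural change alone and stays uncertain. A moderate move towards stronger inhibition is expected, estimated as a 2.8-fold lower number from compound 2 to compound 3 (0.45 log units; beyond the scatter) in this assay, and a result within the scatter would not be surprising. Compound 3 is estimated at 3000 nM with an expected range from 400 nM to 15000 nM on this read-out.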

Compound 3, half-maximal inhibitory concentration: 832 nM
Compound 3: the middle estimate sits 3.6-fold (0.56 log units) above what was measured; measured number inside the range.
By their numbers in this assay, from the lowest: compound 3; then compounds 2 and 1 (each within the scatter of the next).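

In this assay, among these compounds, isopropoxycarbonyl in place of hydrogen on an aromatic carbon, ortho to a chloro group and meta to a large group, gives a 10-fold lower number from compound 2 to compound 3 (1.01 log units; beyond the scatter) and is the first single-place change to read beyond the scatter. This aromatic carbon is therefore not a silent position: it accepts a group of this size, and the read-out moves towards stronger inhibition. Nothing at hand accounts for the size of this step.

On these data alone, whether the response belongs to the ester or to any substituent at this carbon stays open; a carboxylic acid, a methyl ester or a longer alkyl ester at the same carbon would separate these readings. Also open, as far as these compounds go, is whether the step persists with the chloro group replaced by fluoro or hydrogen.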